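The source may hold more compounds than are shown below. What is called first, only, known or untested is meant among the compounds shown, and "the series" means these compounds.

Measured compounds:

Compound 1, `CS/C(=N\C(=O)c1sccc1Cl)NC(=O)c1sccc1Cl`: > 100000 nM
Compound 2, `CS/C(=N\C(=O)c1cc(-c2ccccc2)nc2ccccc12)NC(=O)c1cc(-c2ccccc2)nc2ccccc12`: 48200 nM
Compound 3, `C[Se]/C(=N\C(=O)c1cc(-c2ccccc2)nc2ccccc12)NC(=O)c1cc(-c2ccccc2)nc2ccccc12`: 10100 nM

All three were tested in a functional assay on HepG2 cells (Homo sapiens) for cytotoxicity, read by MTT assay, with a stated time of 72 h; a higher number here means a weaker inhibitor of growth, a lower number a stronger inhibitor of growth. Compound 1 gives only a limit in this assay, > 100000 nM, so no number is known for it, only the edge of what the assay reports; that is the line (the limit of > 100000 nM in this assay, at which 1 of the 3 values shown sits). Compound 2 and compound 3 share one core, and compound 1 sits on a different core; the difference between the two cores is not broken down here.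

Compound 2 and compound 3 differ in one place: a group of 2 heavy atoms (1 carbon, 1 selenium; no ring) in place of a group of 2 heavy atoms (1 carbon, 1 sulfur; no ring), on a carbon with a double bond to nitrogen. With this change the number moved a 4.8-fold lower number from compound 2 to compound 3 (0.68 log units; beyond the scatter).

Compound 4, `C[Se]/C(=N\C(=O)c1sccc1Cl)NC(=O)c1sccc1Cl`, has not yet been measured. It stands to compound 1 as compound 3 stands to compound 2: a group of 2 heavy atoms (1 carbon, 1 selenium; no ring) in place of a group of 2 heavy atoms (1 carbon, 1 sulfur; no ring), on a carbon with a double bond to nitrogen. The place of the change is described in the same words for both pairs, so this is the same change made on the other core.

The expectation for compound 4 rests on two things: the step of a 4.8-fold lower number from compound 2 to compound 3 (0.68 log units; beyond the scatter), which points toward a lower number, and the fact that compound 1 has only a limit, so the starting point for compound 4 is not fixed. If the change acts as it did before, compound 4 is estimated to land an at least 2.0-fold lower number from compound 1 to compound 4 (0.30 log units; that floor lies within the scatter), which still leaves a fair chance that only a limit is reported again. Compound 4 is expected at about 50000 nM, within 15000 nM to 150000 nM.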

Compound 4, concentration for total growth inhibition: 4020 nM
Compound 4: the middle estimate sits 12-fold (1.09 log units) above what was measured; the whole stated range lies above it.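

On the core of compound 1, putting the group of carbon and selenium in place of methylsulfanyl gives an at least 24-fold lower number from compound 1 to compound 4 (1.39 log units; beyond the scatter) in this assay, so the change lowers the number on both cores shown. From the compounds shown here alone, the size of the step, however, does not carry over unchanged from one core to the other, and the gap between the two steps is larger than repeated measurements would explain: the same change on two cores in this assay, a 4.8-fold lower number (0.68 log units; beyond the scatter) from compound 2 to compound 3 and an at least 24-fold lower number (1.39 log units; beyond the scatter) from compound 1 to compound 4, at least 5.2-fold (0.71 log units) apart, beyond the scatter of two such steps Compound 1 has only a limit, > 100000 nM, so the full size of its step remains unknown, and two cores cannot show how the same change would behave on a third core or why the steps differ.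

The compounds shown leave open what other groups would do at this place, on a carbon with a double bond to nitrogen, such as a longer chain like ethyl joined through sulfur or selenium, or an amine. They also leave open whether the same change would lower the number in other cell types, since every value here comes from this assay, and a lower number in these cells says nothing about effects on healthy cells.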